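Solubility notes: imidazolyl to aminopyridinyl on the shared core

The source may hold more compounds than are shown below. What is called first, only, known or untested is meant among the compounds shown, and "the series" means these compounds.

Compound 2 `Cc1cc(C)c(-c2ncc[nH]2)cc1NC(=O)c1ccc(OCc2ccccn2)cc1` carries a methyl where compound 1 `Cc1cc(Cl)c(-c2ncc[nH]2)cc1NC(=O)c1ccc(OCc2ccccn2)cc1` carries a chloro. Within the data shown here, in a physicochemical assay for solubility, at pH 7.4 (a lower number here means a less soluble compound, a higher number a more soluble compound), compound 2 gives 2000 nM, the only plain number in the set. For compound 1 this assay reports a limit rather than a number, < 1000 nM, which is the limit of < 1000 nM in this assay, at which 1 of the 2 values shown sits. Among the measured compounds shown here, the single measured step, an at least 2.0-fold higher number from compound 1 to compound 2 (0.30 log units; that floor lies within the scatter), therefore rests on a limit at its lower end, and compound 2 stands as the one compound with a measured figure.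

Compound 3 `Cc1cc(C)c(-c2ccc(N)cn2)cc1NC(=O)c1ccc(OCc2ccccn2)cc1` differs from compound 2 as follows: 5-aminopyridin-2-yl in place of 1H-imidazol-2-yl on an aromatic carbon. For the measured compounds named here, no measured step concerns this kind of replacement: the step from compound 1 to compound 2 exchanges small groups of a different kind at a different place on the shared core, and it offers no direction for the present change. With nothing in this assay bearing on the entering group, the expected step of no change at the digits printed from compound 2 to compound 3 (within the scatter) is none beyond the scatter, in either direction. Compound 3 is accordingly estimated at 2000 nM, within a range from 700 nM to 6000 nM.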

Compound 3, solubility: < 1000 nM
Compound 3 gave a limit, no number (the forecaster's own chance of this, stated with the estimate: 20%); at least 2.0-fold (0.30 log units) between middle value and limit.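

Working notes on the aromatic carbon ortho to a methyl group and para to a methyl group: in this assay, 5-aminopyridin-2-yl in place of 1H-imidazol-2-yl gives an at least 2.0-fold lower number from compound 2 to compound 3 (0.30 log units; that floor lies within the scatter). Compound 3 gives < 1000 nM, which is a limit and not a number, so this exchange of the whole aromatic ring has a direction on record but no measured size. Each of the two single changes away from compound 2, one at this position and one at the chloro and methyl position, now ends at the same limit, leaving compound 2 as the only compound with a plain number: the limit of < 1000 nM in this assay, at which 2 of the 3 values shown sit.

Going by these compounds, the true size of the step stays open, including whether it reaches beyond the usual scatter. Also open, on these data alone, is whether the ring exchange or the amino group carries the step, which a plain pyridin-2-yl, or a carboxylic acid or a dimethylamino group in place of the amino group, would help to separate.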